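The source may report more compounds than this note shows. Statements on the series, on what has been measured and on what is new or still open speak of the compounds shown alone.

In a functional assay on MDA-MB-231 cells (Homo sapiens) for antiproliferative activity, with a stated time of 4 days (on this read-out lower numbers stand for stronger inhibition and higher numbers for weaker inhibition), compound 1 `CCCCc1ccc2[nH]c(-c3ccc(OC)cc3)c(C=O)c2c1` gives 6.7 nM, compound 2 `CCCCc1ccc2[nH]c(-c3ccc(C(F)(F)F)cc3)c(/C=N/NC(=O)c3ccccc3)c2c1` gives 300 nM, and compound 3 `CCCCc1ccc2[nH]c(-c3ccc(OC)cc3)c(/C=N/NC(=O)c3ccccc3OC)c2c1` gives 21 nM. Compound 3 therefore sits in the middle of these three numbers, and its gap to each of the others lies beyond the scatter. Compound 4 `CCCCc1ccc2[nH]c(-c3ccc(OC)cc3)c(/C=N/NC(=O)c3ccccn3)c2c1` changes one part of compound 3: pyridin-2-yl replaces 2-methoxyphenyl on a carbonyl carbon (pyridin-2-yl in place of 2-methoxyphenyl on a carbonyl carbon). For the measured compounds named here, no measured pair shows this change on its own, so any expectation here remains uncertain. The estimated step of a 1.4-fold higher number from compound 3 to compound 4 (0.15 log units; within the scatter) is small, towards slightly weaker inhibition, and is expected to stay within the scatter. For compound 4, the expected value is 30 nM, with an estimated range of 10 nM to 100 nM.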

Compound 4, half-maximal inhibitory concentration: 34 nM
Compound 4: the middle estimate sits 1.1-fold (0.05 log units) below what was measured; the measured number falls inside the stated range.
By their numbers in this assay, from the lowest: compound 1; then compounds 3 and 4 (each within the scatter of the next); then compound 2.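

In this assay, placing pyridin-2-yl instead of 2-methoxyphenyl on the carbonyl carbon gives a 1.6-fold higher number from compound 3 to compound 4 (0.21 log units; within the scatter) and so leaves the two compounds indistinguishable. This position therefore accepts a smaller six-membered aromatic ring containing a ring nitrogen in place of the carbon-only ring and its methoxy group, at least in this pair. Nothing available explains why the two compounds read alike.

From the compounds shown here alone, it remains open whether this tolerance extends beyond aromatic rings. A methyl group or a saturated ring such as cyclohexyl on the same carbonyl carbon would test that.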